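This account rests on a few compounds, and the source may have more. Where it says the series, first, only, none or still open, it means among the compounds named here.

Measured so far, in a functional assay on the whole organism with Rattus norvegicus as the target, at a dose of 20 mg/kg by the oral route; on this read-out higher numbers stand for more inhibition at the one dose given (going by the name of the read-out) and lower numbers for less inhibition:
- compound 1 `Cc1cccc2c1CC/C2=C\C(=O)NC1CC1`: 15%
- compound 2 `CC(C)NC(=O)/C=C1\CCc2ccc(F)cc21`: 45%
- compound 3 `COc1ccc2c(c1)/C(=C/C(N)=O)CC2`: 1%

Compound 2 holds the highest of the three numbers in this assay. Compound 1 sits lower by a margin beyond the scatter, and compound 3 lower still, also beyond the scatter. Each of the three differs from the others in more than one place, so none of these gaps can be tied to a single structural change.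

Compound 4 `CCCNC(=O)/C=C1\CCc2ccc(F)cc21` is the next candidate. It differs from compound 2 as follows: propyl in place of isopropyl on an amide-type nitrogen. Propyl and isopropyl carry the same atoms joined differently, and nothing among the measured compounds shows what a change of this kind on the amide-type nitrogen does in this assay. On that basis the expected step is a number 5 percentage points lower from compound 2 to compound 4 (within the scatter), which lies within the scatter rather than a change in either direction. Compound 4 is therefore estimated at 40%, with a range from 18% to 62%.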

Compound 4, a percentage reported as inhibition, in the whole organism at one dose (the size of the read-out at that dose, not a potency): 0%
For compound 4 the middle estimate is 40 percentage points above the measured one; measured number below the stated range.
By their numbers in this assay, from the lowest: compounds 4 and 3 (each within the scatter of the next); then compound 1; then compound 2.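

On the amide-type nitrogen, in this assay the exchange of isopropyl for propyl gives a number 45 percentage points lower from compound 2 to compound 4 (beyond the scatter) with the same atoms joined differently. Going by these compounds alone, this is the first step that can be tied to one place, and it shows that the read-out at this position depends on how the three carbons are joined, not only on how many there are. Nothing available here bears on why the two groups give such different numbers.

Within the data shown here, whether the branch itself matters or only this pair differs stays open; a tert-butyl or a butyl chain on this nitrogen, on the core of compound 2, would test it. The cyclopropyl of compound 1 and the unsubstituted amide of compound 3 sit on other cores and cannot settle the question.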